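The compounds below may be only part of what the source reports. "The series", "measured", "known", "first", "only" and "open" are said of these compounds alone.

Of the compounds shown here, three built on a shared core have been measured in a functional assay on B16-F0 cells (Mus musculus) for inhibition, read by CCK-8 assay, with a stated time of 48 h; a higher number here means a weaker inhibitor, a lower number a stronger inhibitor. Compound 1 `COc1ccc(-c2cc3nccc(-c4cc(OC)c(OC)c(OC)c4)n3n2)cc1` gives 1410 nM in this assay. Compound 2 `CCOC(=O)c1ccc(-c2cc3nccc(-c4cc(OC)c(OC)c(OC)c4)n3n2)cc1` carries an ethoxycarbonyl group where compound 1 has a methoxy. In this assay compound 2 reaches only the limit, recorded as > 10000 nM. Compound 3 `COc1cc(-c2ccnc3cc(-c4cn(C)c5ccccc45)nn23)cc(OC)c1OC` gives 185 nM in this assay, the lowest of the two plain numbers; the step of a 7.6-fold lower number from compound 1 to compound 3 (0.88 log units; beyond the scatter) came with 1-methyl-1H-indol-3-yl in place of 4-methoxyphenyl. The third value, that of compound 2, is a limit of the assay.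

Compound 4 `COc1cc(-c2ccnc3cc(-c4ccc(C(F)(F)F)cc4)nn23)cc(OC)c1OC` is not yet measured. It differs from compound 3 by 4-(trifluoromethyl)phenyl in place of 1-methyl-1H-indol-3-yl on an aromatic carbon. Going by the values given here, two measured steps bear on this change. The step of a 7.6-fold lower number from compound 1 to compound 3 (0.88 log units; beyond the scatter) shows that the indolyl group brought a lower number than a substituted phenyl, and the step of an at least 7.0-fold higher number from compound 1 to compound 2 (0.85 log units; beyond the scatter) shows that swapping the group on such a phenyl pushed the number up to the limit of > 10000 nM in this assay, at which 1 of the 3 values shown sits. Compound 4 goes back to a substituted phenyl, so in this assay a higher number than for compound 3 is expected, most likely of the size a 16-fold higher number from compound 3 to compound 4 (1.21 log units; beyond the scatter). Compound 4 is therefore estimated at 3000 nM, with a range from 800 nM to 12000 nM.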

Compound 4, half-maximal inhibitory concentration: 1770 nM
For compound 4 the middle estimate is 1.7-fold (0.23 log units) above the measured one; low and high end bracket the measured number.
By their numbers in this assay, from the lowest: compound 3; then compounds 1 and 4 (each within the scatter of the next). At a limit, above all of these: compound 2.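

Two different groups on the phenyl ring now give values that cannot be told apart in this assay, a 1.3-fold higher number from compound 1 to compound 4 (0.10 log units; within the scatter), while the indolyl group keeps its lead over this second substituted phenyl as well, a 9.6-fold higher number from compound 3 to compound 4 (0.98 log units; beyond the scatter). So at this place on the five-membered aromatic ring, the gain seen with 1-methyl-1H-indol-3-yl no longer rests on a comparison with 4-methoxyphenyl alone, and the loss seen with ethoxycarbonyl does not extend to every replacement of methoxy, an at least 5.6-fold lower number from compound 2 to compound 4 (0.75 log units; beyond the scatter). That last step is measured from a value that is not a number, so its true size is unknown, and compound 2 stays a limit of the assay: the limit of > 10000 nM in this assay, at which 1 of the 4 values shown sits.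

The compounds shown leave open whether a phenyl ring carrying an amine, a carboxylic acid or a longer chain would stay with compounds 1 and 4 or fall away like compound 2. They also do not tell which part of the indolyl group carries its lead, since a plain indole without the methyl group or a simple unsubstituted phenyl would be needed to separate those parts.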